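Swapping 2-Phenylethenyl for Furan-2-yl on a Shared Core

This account rests on a few compounds, and the source may have more. Where it says the series, first, only, none or still open, it means among the compounds named here.

Of the compounds shown here, three built on one shared core have been measured in a functional assay on Ehrlich cells (Mus musculus) for antiproliferative activity, read by trypan blue exclusion, with a stated time of 2 h, tested at 10 ug/mL; on this read-out lower numbers stand for a weaker effect and higher numbers for a stronger effect at the one concentration tested. Compound 1 `Cc1ccc(C2C(C#N)=C(N)N(c3ccc(S(N)(=O)=O)cc3)C3=C2C(=O)CCC3)cc1` gives 30%. Compound 2 `N#CC1=C(N)N(c2ccc(S(N)(=O)=O)cc2)C2=C(C(=O)CCC2)C1/C=C/c1ccccc1` gives 2%, the lowest of the three numbers. Compound 3 `N#CC1=C(N)N(c2ccc(S(N)(=O)=O)cc2)C2=C(C(=O)CCC2)C1c1cccc([N+](=O)[O-])c1` gives 42%, the highest. Compound 2 thus stands at the bottom: the step of a number 28 percentage points lower from compound 1 to compound 2 (beyond the scatter) shows the number falling when 2-phenylethenyl replaces 4-methylphenyl, while a number 40 percentage points higher from compound 2 to compound 3 (beyond the scatter) shows it rising strongly when 3-nitrophenyl replaces 2-phenylethenyl. Between the two compounds that carry a six-membered aromatic ring at that position, the step of a number 12 percentage points higher from compound 1 to compound 3 (beyond the scatter) is smaller.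

Compound 4 `N#CC1=C(N)N(c2ccc(S(N)(=O)=O)cc2)C2=C(C(=O)CCC2)C1c1ccco1` has not yet been measured. It differs from compound 2 in one place: furan-2-yl in place of 2-phenylethenyl on a saturated ring carbon. Going by the values given here, the steps that bear on this change are the two that remove or install the 2-phenylethenyl group, a number 28 percentage points lower from compound 1 to compound 2 (beyond the scatter) and a number 40 percentage points higher from compound 2 to compound 3 (beyond the scatter), both beyond the scatter and both pointing the same way: an aromatic ring on that saturated ring carbon goes with higher numbers than the 2-phenylethenyl chain. Furan-2-yl is also an aromatic ring, though a five-membered one with 1 hetero atom, so the size of the gain is less certain. A rise in this assay is therefore expected, of moderate size, a number 23 percentage points higher from compound 2 to compound 4 (beyond the scatter). Compound 4 is estimated at 25%, with a range from 8% to 45%.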

Compound 4, a percentage reported as activity, at one concentration (the size of the read-out at that concentration, not a potency): 0%
For compound 4 the middle estimate is 25 percentage points above the measured one; the whole stated range lies above it.
By their numbers in this assay, from the lowest: compounds 4 and 2 (each within the scatter of the next); then compound 1; then compound 3.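

In this assay the change from 2-phenylethenyl to furan-2-yl gives a number 2 percentage points lower from compound 2 to compound 4 (within the scatter) and so does not separate these two groups on this saturated ring carbon, although furan-2-yl is an aromatic ring attached there. The other two changes give a number 42 percentage points lower from compound 3 to compound 4 (beyond the scatter) and a number 30 percentage points lower from compound 1 to compound 4 (beyond the scatter) and place compound 4 far from both compounds that carry a substituted six-membered aromatic ring, so among these four compounds an aromatic ring at this carbon is not enough for a higher number, and compound 4 goes against that simpler reading. No supporting measurement is available to explain this result.

The compounds shown do not tell whether what counts is the five-membered ring, its oxygen atom, or the substituent that compound 1 and compound 3 carry on their six-membered ring. A thiophen-2-yl group, which has sulfur in place of the oxygen, and a plain phenyl group without any substituent would help to separate these possibilities on the shared core.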